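Bromo for ethynyl on the nitroimidazole series

The source may report more compounds than this note shows. Statements on the series, on what has been measured and on what is new or still open speak of the compounds shown alone.

Values in a functional assay on HT-29 cells (Homo sapiens) for inhibition, read by sulforhodamine B assay, with a stated time of 72 h (a lower number here means a stronger inhibitor, a higher number a weaker inhibitor), follow.
- Compound 1 `C#Cc1cccc(Nc2ncnc3cc(OCCCCn4ccnc4[N+](=O)[O-])c(OC)cc23)c1` gives 590 nM
- Compound 2 `C#Cc1cccc(Nc2ncnc3cc(OCCCCCn4ccnc4[N+](=O)[O-])c(OC)cc23)c1` gives 280 nM
- Compound 3 `C#Cc1cccc(Nc2ncnc3cc(OCCOCCn4ccnc4[N+](=O)[O-])c(OC)cc23)c1` gives 6040 nM

Compound 1 holds the middle of these numbers, with a 2.1-fold lower number from compound 1 to compound 2 (0.32 log units; beyond the scatter) and a 10-fold higher number from compound 1 to compound 3 (1.01 log units; beyond the scatter). Compound 4 `COc1cc2c(Nc3cccc(Br)c3)ncnc2cc1OCCCCn1ccnc1[N+](=O)[O-]` has bromo in place of ethynyl on an aromatic carbon, meta to a large group: bromo in place of ethynyl on an aromatic carbon. Within the data shown here, no measured step touches this position. All three change the chain, the largest being a 22-fold higher number from compound 2 to compound 3 (1.33 log units; beyond the scatter), so they give no size for this swap. The expectation therefore starts from compound 1 at 590 nM, with no step beyond the scatter expected in this assay and no firm direction. The expected step is a 1.2-fold lower number from compound 1 to compound 4 (0.07 log units; within the scatter). Compound 4 is estimated at 500 nM, with an expected range of 170 nM to 1500 nM.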

Compound 4, half-maximal inhibitory concentration: 1430 nM
Beside the measured number, compound 4's estimate is 2.9-fold (0.46 log units) below it; low and high end bracket the measured number.
By their numbers in this assay, from the lowest: compound 2; then compound 1; then compound 4; then compound 3.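

The aromatic carbon of the 3-ethynylphenyl group is not a silent position: in this assay, bromo in place of ethynyl gives a 2.4-fold higher number from compound 1 to compound 4 (0.38 log units; beyond the scatter). This first step away from the chain changes shows that ethynyl reads better than bromo here, although the change is modest beside the large chain step, a 10-fold higher number from compound 1 to compound 3 (1.01 log units; beyond the scatter). Nothing measured here explains the step.

Still open, from the compounds shown here alone, is whether bromo shifts the number similarly on the chains of compound 2 and compound 3. Going by these compounds, how chloro or nitrile would read on this carbon also remains open.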